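The source may hold more compounds than are shown below. What is called first, only, known or untested is meant among the compounds shown, and "the series" means these compounds.

Working notes on the series.

Compound 1 `COc1ccc(-c2cc3c(OC)cc(OC)cc3n(CC#N)c2=O)cc1` is the reference. In a functional assay on MCF7 cells (Homo sapiens) for cytotoxicity, read by colorimetric assay and MTT assay (a higher number here means a weaker inhibitor, a lower number a stronger inhibitor), compound 1 gives 10000 nM. Compound 2 `COc1ccc(-c2cc3c(OC)cc(OC)cc3n(CC(=O)OCc3ccccc3)c2=O)cc1` carries the change (benzyloxycarbonyl in place of cyano on a saturated chain carbon bound to an aromatic nitrogen); in this assay compound 2 gives 10000 nM, and the step of no change at the digits printed from compound 1 to compound 2 (within the scatter) is flat. Compound 3 `COc1ccc(-c2cc3c(OC)cc(OC)cc3n(CCC#N)c2=O)cc1` differs from compound 1 by cyanomethyl in place of cyano on a saturated chain carbon bound to an aromatic nitrogen; in this assay compound 3 gives 10000 nM, with no change at the digits printed from compound 1 to compound 3 (within the scatter) and no change at the digits printed from compound 2 to compound 3 (within the scatter) both flat as well. The three measured compounds therefore stand together at one value, and nothing among them separates one chain from another.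

Compound 4 `COc1ccc(-c2cc3c(OC)cc(OC)cc3n(CCC(=O)OCc3ccccc3)c2=O)cc1` is not yet measured. It differs from compound 3 by benzyloxycarbonyl in place of cyano on a saturated chain carbon, two bonds along the chain from an aromatic nitrogen. For the measured compounds named here, this is the same kind of change as the one from compound 1 to compound 2, but not the same: there the place is on a saturated chain carbon bound to an aromatic nitrogen, here it is on a saturated chain carbon, two bonds along the chain from an aromatic nitrogen. The two cores differ by cyanomethyl in place of cyano on a saturated chain carbon bound to an aromatic nitrogen.

Because the earlier step of no change at the digits printed from compound 1 to compound 2 (within the scatter) is flat, and because compound 3 sits at 10000 nM with the other two, the step from compound 3 to compound 4 is expected to be flat too, about no change at the digits printed from compound 3 to compound 4 (within the scatter). Compound 4 is therefore estimated to give 10000 nM in this assay, expected to fall between 5000 nM and 20000 nM.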

Compound 4, half-maximal inhibitory concentration: 10000 nM
Estimate against measurement, compound 4: no gap at the digits printed; measured number inside the range.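

In this assay the new step reads no change at the digits printed from compound 3 to compound 4 (within the scatter), and the two other steps that end at this compound read no change at the digits printed from compound 2 to compound 4 (within the scatter) and no change at the digits printed from compound 1 to compound 4 (within the scatter). Benzyloxycarbonyl in place of cyano therefore behaves alike on the core of compound 1 and on the core of compound 3, with the two steps agreeing: the same change on two cores in this assay, no change at the digits printed (within the scatter) from compound 1 to compound 2 and no change at the digits printed (within the scatter) from compound 3 to compound 4, 1.0-fold (0.00 log units) apart, within the scatter of two such steps This shows only that the change leaves the read-out flat on both cores; since all four compounds stand at one value, it does not show that a step of visible size would carry from one core to the other, and it gives no order among the four chains.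

The compounds shown leave open whether any group on this chain can move the value away from the level shared by compounds 1 to 4, for example a carboxylic acid or an amine in place of benzyloxycarbonyl, or a longer chain. They also leave open whether hydroxyl in place of methoxy on the shared core would change the picture, and whether the flat steps would then still hold from one core to the other.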